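This account rests on a few compounds, and the source may have more. Where it says the series, first, only, none or still open, it means among the compounds named here.

The measured compounds and their numbers in an ADME assay on NIH3T3 cells (Homo sapiens) for cytotoxicity, read by sulforhodamine B assay, with a stated time of 48 h (a higher number here means a weaker inhibitor, a lower number a stronger inhibitor), are:

compound 1 `CC(=O)OC[C@H]1O[C@@H](n2cc(CN3C(=O)/C(=C\C=C\c4ccccc4)c4ccccc43)nn2)[C@H](OC(C)=O)[C@@H](OC(C)=O)[C@@H]1OC(C)=O`: 25900 nM
compound 2 `CC(=O)OC[C@H]1O[C@@H](n2cc(CN3C(=O)/C(=C\c4ccc(N(C)C)cc4)c4ccccc43)nn2)[C@H](OC(C)=O)[C@@H](OC(C)=O)[C@@H]1OC(C)=O`: 17000 nM
compound 3 `CC(=O)OC[C@H]1O[C@@H](n2cc(CN3C(=O)/C(=C/c4cccs4)c4ccccc43)nn2)[C@H](OC(C)=O)[C@@H](OC(C)=O)[C@@H]1OC(C)=O`: 48100 nM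

Compound 3 holds the highest of these three numbers in this assay. Its nearest neighbour is compound 1, and the gap between those two values lies within the scatter; the gap from compound 3 to compound 2 lies beyond it. Compound 4 `CC(=O)OC[C@H]1O[C@@H](n2cc(CN3C(=O)/C(=C\c4cccs4)c4ccccc43)nn2)[C@H](OC(C)=O)[C@@H](OC(C)=O)[C@@H]1OC(C)=O` is the next compound to be examined, and it differs from compound 3 in a single respect: the two compounds have the same atoms and bonds and differ only in configuration as drawn: 1 of 6 stereo elements differ; a double bond is drawn E in compound 3 and Z in compound 4. The only measured step among these compounds is a 1.5-fold lower number from compound 1 to compound 2 (0.18 log units; within the scatter), which exchanges one group for another on the exocyclic double bond and does not touch the drawn geometry of that bond; it therefore bears only loosely on the present change. Among the measured compounds shown here, no measured pair differs solely in the configuration of the double bond, so nothing in the numbers so far gives a direction for this move. On that basis no step beyond the scatter is expected, and the estimated step is a 1.1-fold lower number from compound 3 to compound 4 (0.03 log units; within the scatter). Compound 4 is accordingly expected to give about 45000 nM in this assay, with an estimated range from 18000 nM to 110000 nM.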

Compound 4, half-maximal inhibitory concentration: 14600 nM
Compound 4: the middle estimate sits 3.1-fold (0.49 log units) above what was measured; the measured number lies below the stated range.
By their numbers in this assay, from the lowest: compounds 4, 2, 1 and 3 (each within the scatter of the next, the first and the last beyond it).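

In this assay the configuration of the double bond carrying thiophen-2-yl matters by itself, with a 3.3-fold lower number from compound 3 to compound 4 (0.52 log units; beyond the scatter), and this step can be set on that configuration alone because nothing else separates the two structures: the fact that compounds 3 and 4 differ only in the configuration as drawn

The exchanges of group read differently, with a 1.2-fold lower number from compound 2 to compound 4 (0.07 log units; within the scatter) and a 1.8-fold lower number from compound 1 to compound 4 (0.25 log units; within the scatter), both within the scatter, as was the earlier exchange, so thiophen-2-yl, 4-(dimethylamino)phenyl and 2-phenylethenyl are not told apart in these pairs. Among the steps shown at this position, only the change of configuration lies beyond the scatter, which the earlier compounds, with their single exchange of group, could not show.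

The compounds shown leave open whether the configuration of the double bond counts in the same way with 4-(dimethylamino)phenyl or 2-phenylethenyl, as thiophen-2-yl is the only group seen here in both forms. Also open, as far as these compounds go, is how an amine or a carboxylic acid in place of thiophen-2-yl would read in either configuration.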